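This account rests on a few compounds, and the source may have more. Where it says the series, first, only, none or still open, it means among the compounds named here.

In an ADME assay on HeLa cells (Homo sapiens) for cytotoxicity, read by sulforhodamine B assay, with a stated time of 48 h, tested at 10 uM (a lower number here means less inhibition, a higher number more inhibition at the concentration tested (going by the name of the read-out)), compound 2 `CCCCCCCCc1cn(C(c2ccccc2)c2cc3cc(Br)ccc3nc2OC)nn1` gives 0.1%, the second highest of three numbers; its nearest neighbour is compound 1 `CCCCCCc1cn(C(c2ccccc2)c2cc3cc(Br)ccc3nc2OC)nn1` with -0.97%, and its furthest is compound 3 `COc1nc2ccc(Br)cc2cc1C(c1ccccc1)n1cc(-c2ccc(F)cc2)nn1` with 4.27%. Compound 4 `COc1nc2ccc(Br)cc2cc1C(c1ccccc1)n1cc(CCCCCO)nn1` differs from compound 2 by hydroxy in place of propyl on a saturated chain carbon, five bonds along the chain from an aromatic carbon. The measured steps that bear on this change, a number 1.1 percentage points higher from compound 1 to compound 2 (within the scatter), a number 4.2 percentage points higher from compound 2 to compound 3 (within the scatter) and a number 5.2 percentage points higher from compound 1 to compound 3 (within the scatter), were each within the scatter. None of them moved the read-out beyond the scatter, and so the step in this assay from compound 2 to compound 4 is expected to be a number 1.9 percentage points higher from compound 2 to compound 4 (within the scatter), with no movement beyond the scatter. Compound 4 is therefore estimated at 2%, with a range from -8% to 12%.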

Compound 4, a percentage reported as inhibition, at one concentration (the size of the read-out at that concentration, not a potency): 1.08%
For compound 4 the middle estimate is 0.9 percentage points above the measured one; the range from low to high includes it.
By their numbers in this assay, from the lowest: compounds 1, 2, 4 and 3 (each within the scatter of the next).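

In this assay, hydroxy on a saturated chain carbon, five bonds along the chain from an aromatic carbon, stays within the scatter of both plain alkyl chains (a number 1 percentage points higher from compound 2 to compound 4 (within the scatter); a number 2.1 percentage points higher from compound 1 to compound 4 (within the scatter)). The 5-hydroxypentyl group is likewise within the scatter of 4-fluorophenyl (a number 3.2 percentage points lower from compound 3 to compound 4 (within the scatter)), so a chain ending in hydroxy joins the alkyl chains and the aryl group without separating from either. Nothing available explains the size of these steps. Going by these compounds, whether an amine or a carboxylic acid at the chain end would move the read-out beyond the scatter remains open. So does the effect of a longer chain ending in hydroxy.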